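The compounds below may be only part of what the source reports. "The series", "measured", "known", "first", "only" and "open" are said of these compounds alone.

Measured so far:
compound 1 `COc1cc(C(=O)c2sc(-c3ccc(I)cc3)cc2N)cc(OC)c1OC`: 150 nM
compound 2 `COc1cc(C(=O)c2sc(-c3cc(OC)c(OC)c(OC)c3)cc2N)cc(OC)c1OC`: 840 nM

Both numbers come from a functional assay on CCRF-CEM cells (Homo sapiens) for antiproliferative activity; a higher number here means a weaker inhibitor, a lower number a stronger inhibitor. Compound 1 stands lowest of the two; compound 2 sits higher by a margin beyond the scatter. Going by the values given here, no pair of measured compounds differs in a single place, so the two values give only a rough picture of what replacing the group on the shared core does.

Compound 3 `COc1cc(C(=O)c2sc(-c3cccs3)cc2N)cc(OC)c1OC` differs from compound 1 in one place: thiophen-2-yl in place of 4-iodophenyl on an aromatic carbon. The entering group is smaller and is a five-membered aromatic ring with 1 hetero atom in place of a six-membered aromatic ring of carbon only. The only other variation seen at this place, compound 2, gives 840 nM, a weaker result than compound 1. An upward step beyond the scatter is expected, a 4.0-fold higher number from compound 1 to compound 3 (0.60 log units; beyond the scatter), though with wide uncertainty. For compound 3 the estimate in this assay is 600 nM, with a range from 150 nM to 2500 nM.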

Compound 3, half-maximal inhibitory concentration: 9.4 nM
Beside the measured number, compound 3's estimate is 64-fold (1.81 log units) above it; measured number below the stated range.
By their numbers in this assay, from the lowest: compound 3; then compound 1; then compound 2.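

In this assay, this position on the shared core, on an aromatic carbon next to the ring sulfur, proves highly sensitive to the group it carries: thiophen-2-yl in place of 4-iodophenyl gives a 16-fold lower number from compound 1 to compound 3 (1.20 log units; beyond the scatter). The change shows that a six-membered aromatic ring of carbon only is not needed here and that a smaller five-membered aromatic ring with 1 sulfur can give a much stronger result than 4-iodophenyl. No measurement is available to explain this step.

This single step does not separate the effect of ring size, the ring sulfur and the loss of iodine. From the compounds shown here alone, whether the stronger result is specific to thiophen-2-yl remains open, and unsubstituted phenyl, thiophen-3-yl or furan-2-yl at this position would help to distinguish these factors.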